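The compounds below may be only part of what the source reports. "The series", "measured", "known", "first", "only" and "open" are said of these compounds alone.

Of the compounds shown here, three that share one core have been tested in a functional assay on A-375 cells (Homo sapiens) for antiproliferative activity, read by CCK-8 assay, with a stated time of 72 h, tested at 2 uM; a higher number here means a stronger effect of the compound at the concentration tested, a lower number a weaker effect. Compound 1 `CC1CCN(C(=S)SCc2ccc(C(=O)Nc3ccccc3N)cc2)CC1` gives 32.7%. For the measured compounds named here, compound 2 `Nc1ccccc1NC(=O)c1ccc(CSC(=S)N2CCN(Cc3ccncc3)CC2)cc1` gives 33.1%, a number within the scatter of the one for compound 1. Compound 3 `Nc1ccccc1NC(=O)c1ccc(CSC(=S)N2CCN(c3ccc(F)cc3)CC2)cc1` gives 20.9%, which is below the number for compound 1 by more than the scatter. Compound 1 thus sits second highest of the three, close to compound 2 and clearly above compound 3.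

Compound 4 `Nc1ccccc1NC(=O)c1ccc(CSC(=S)N2CCCC2)cc1` has not been measured. It differs from compound 1 in one place: pyrrolidin-1-yl in place of 4-methylpiperidin-1-yl on a thiocarbonyl carbon. Going by the values given here, the only measured step, a number 12.2 percentage points lower from compound 2 to compound 3 (beyond the scatter), concerns a change on the amine nitrogen of a ring rather than on the thiocarbonyl carbon, so it bears on the present change only loosely; it shows that changing the group attached to the thiocarbonyl region can move the number by a modest amount. Among the compounds with values here, no step in the data tells the direction for a smaller ring at this site. The expectation is therefore a step of roughly a number 3.7 percentage points lower from compound 1 to compound 4 (within the scatter), not clearly beyond the scatter. Compound 4 is estimated at 29%, with a range from 17% to 41%.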

Compound 4, a percentage reported as inhibition, at one concentration (the size of the read-out at that concentration, not a potency): 30.2%
The estimate for compound 4 lay 1.2 percentage points below the measured number; the measured number falls inside the stated range.
By their numbers in this assay, from the lowest: compounds 3, 4, 1 and 2 (each within the scatter of the next, the first and the last beyond it).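

For the compounds shown here, replacing 4-methylpiperidin-1-yl with pyrrolidin-1-yl on a thiocarbonyl carbon gives, in this assay, a number 2.5 percentage points lower from compound 1 to compound 4 (within the scatter), the first direct reading of a change at this position. At this single concentration, the read-out does not separate the five-membered ring from the six-membered ring bearing a methyl group, so this position tolerates this particular swap without a clear loss or gain. No supporting measurement is available to explain this result. Still open, on these data alone, is whether an open-chain group such as diethylamino, or a morpholine ring with its added oxygen, on the thiocarbonyl carbon would move the number beyond the scatter. A reading at one concentration also leaves open whether compound 1 and compound 4 would differ in potency across a range of concentrations.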